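A Larger Aromatic Substituent on the Shared Core

The compounds below may be only part of what the source reports. "The series", "measured", "known", "first", "only" and "open" are said of these compounds alone.

This account compares compound 1 `CCCn1c(NCCO)nc2nc(C3CCCC3)[nH]c2c1=O` with compound 3 `CCCn1c(NCc2ccc(C(=O)O)cc2)nc2nc(C3CCCC3)[nH]c2c1=O`. Among the compounds with values here, in an assay on HEK293 cells for displacement of a labelled ligand from adenosine receptor A1 (Homo sapiens), with a stated time of 90 min, tested at 1 uM (a higher number here means more inhibition at the concentration tested (going by the name of the read-out), a lower number less inhibition), compound 1 gives 36%, the lower of the two numbers known, while compound 2 `CCCn1c(-c2ccc(C(F)(F)F)cc2)nc2nc(C3CCCC3)[nH]c2c1=O` gives 70%, a gap beyond the usual scatter. Compound 3 differs from compound 1 by 4-carboxyphenyl in place of hydroxymethyl on a saturated chain carbon bound to a nitrogen on an aromatic ring. Within the data shown here, no step between measured compounds matches this change, so the expectation rests on the two values alone. Compound 3 is expected to sit at 50%, in the range 25% to 75%. The expected step of a number 14 percentage points higher from compound 1 to compound 3 (beyond the scatter) is thus a modest rise, though it may lie within the scatter.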

Compound 3, a percentage reported as inhibition, at one concentration (the size of the read-out at that concentration, not a potency): 54%
Compound 3: middle estimate off by 4 percentage points, on the low side; the range from low to high includes it.
By their numbers in this assay, from the lowest: compound 1; then compound 3; then compound 2.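

The step of a number 18 percentage points higher from compound 1 to compound 3 (beyond the scatter) in this assay shows that this place, a saturated chain carbon bound to a nitrogen on an aromatic ring, accepts 4-carboxyphenyl in place of hydroxymethyl without a loss of inhibition. The much larger group, with its six-membered aromatic ring, goes with a modest rise at the concentration tested.

As far as these compounds go, because the change brings in the ring and the carboxylic acid together, the share of each stays open. A plain phenyl group or an amine on that ring would separate them. No supporting measurement bears on why the number rises.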